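Replacing a dimethylphenyl with a methylpyridinyl on the shared core

The source may report more compounds than this note shows. Statements on the series, on what has been measured and on what is new or still open speak of the compounds shown alone.

Compound 3, `Cc1ccc(C)c(-c2ncnc3c2cnn3CCN2CCCCC2)c1`, gives 63 nM in an assay on HEK293 cells for displacement of a labelled ligand from Sigma non-opioid intracellular receptor 1 (Homo sapiens), read by scintillation counting, with a stated time of 120 min (on this read-out higher numbers stand for weaker inhibition and lower numbers for stronger inhibition), the lowest number of the three measured compounds. Compound 2, `Cc1cccc(-c2ncnc3c2cnn3CCN2CCCCC2)c1`, gives 82 nM, and the step of a 1.3-fold lower number from compound 2 to compound 3 (0.11 log units; within the scatter) lies within the scatter, so the two cannot be told apart. Compound 1, `c1cn(-c2ncnc3c2cnn3CCN2CCCCC2)cn1`, gives 13800 nM; the steps of a 170-fold lower number from compound 1 to compound 2 (2.23 log units; beyond the scatter) and a 220-fold lower number from compound 1 to compound 3 (2.34 log units; beyond the scatter) are large, showing that a ring of carbon only carrying methyl groups sits far better here than 1H-imidazol-1-yl.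

Compound 4, `Cc1ccncc1-c1ncnc2c1cnn2CCN1CCCCC1`, differs from compound 3 by 4-methylpyridin-3-yl in place of 2,5-dimethylphenyl on an aromatic carbon. The new ring keeps one methyl and an all-carbon ring is exchanged for one with a single nitrogen, a milder version of the change behind the large step from compound 1. Within the data shown here, no measured step covers a pyridine directly, so the expected size is uncertain, but some loss is expected: the estimated step is a 4.8-fold higher number from compound 3 to compound 4 (0.68 log units; beyond the scatter), and compound 4 is expected to give about 300 nM in this assay, with a likely range of 80 nM to 1500 nM.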

Compound 4, inhibition constant: 707 nM
For compound 4 the middle estimate is 2.4-fold (0.37 log units) below the measured one, and the stated range covers the measured number.
By their numbers in this assay, from the lowest: compounds 3 and 2 (each within the scatter of the next); then compound 4; then compound 1.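

At this position, a six-membered aromatic ring carrying a methyl does not by itself secure the low numbers of the carbon-only rings: swapping in 4-methylpyridin-3-yl gives an 11-fold higher number from compound 3 to compound 4 (1.05 log units; beyond the scatter) and an 8.6-fold higher number from compound 2 to compound 4 (0.94 log units; beyond the scatter) in this assay. Yet the same group still gives a 20-fold lower number from compound 1 to compound 4 (1.29 log units; beyond the scatter), so the response at this position is graded rather than all-or-nothing, with 4-methylpyridin-3-yl falling between the carbon-only rings and 1H-imidazol-1-yl. No supporting data are available to explain why the pyridine ring gives this intermediate result.

Compound 4 differs from compound 3 in both its ring nitrogen and its methyl pattern. The measured compounds do not separate these two changes. Also open, as far as these compounds go, is how a plain phenyl, or a phenyl carrying methoxy or chlorine, would behave here.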